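The compounds below may be only part of what the source reports. "The series", "measured", "known", "first", "only" and "open" are said of these compounds alone.

Compound 2 `O=S(=O)(c1cc(Cl)cc(Cl)c1)c1cnc2cc(F)ccc2c1-c1cccc(F)c1` and compound 3 `O=S(=O)(c1cc(Cl)cc(Cl)c1)c1cnc2cc(F)ccc2c1-c1cccc(Cl)c1` share one core and differ in one place only: chloro in place of fluoro on an aromatic carbon. In an ADME assay on microsomes from liver (Homo sapiens) for metabolic stability, tested at 2.5 uM (a lower number here means slower removal, a higher number faster removal of the compound), compound 2 gives 0.41 mL/min, and compound 3 gives 0.93 mL/min. The step reads a 2.3-fold higher number from compound 2 to compound 3 (0.36 log units; beyond the scatter).

Compound 1 `O=S(=O)(c1ccc(F)cc1)c1cnc2cc(F)ccc2c1-c1ccc(F)cc1` sits on a different core; the difference between the two cores is not broken down here. In this assay compound 1 gives 1.34 mL/min, the highest of the three numbers, with compound 3 within the scatter of it and compound 2 beyond.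

Compound 4 `O=S(=O)(c1ccc(F)cc1)c1cnc2cc(F)ccc2c1-c1ccc(Cl)cc1` is the untested analogue of compound 1, and the change from compound 1 to compound 4 is chloro in place of fluoro on an aromatic carbon. Among the compounds with values here, this is the same kind of change as the one from compound 2 to compound 3, though not the same: there the chlorine enters meta to a large group, here it enters para to a large group, and the surrounding core differs as well. Within the data shown here, with only one measured example of this change, the expectation rests on that single step. Compound 4 is expected to show a 2.2-fold higher number from compound 1 to compound 4 (0.35 log units; beyond the scatter), a step of about the size seen in a 2.3-fold higher number from compound 2 to compound 3 (0.36 log units; beyond the scatter), because compound 1 starts from 1.34 mL/min. The estimate for compound 4 in this assay is therefore 3 mL/min, with a range from 1.5 mL/min to 6 mL/min.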

Compound 4, intrinsic clearance in a liver preparation (reported as CLH), per the amount of preparation that the assay uses: 1.23 mL/min
The estimate for compound 4 lay 2.4-fold (0.39 log units) above the measured number, outside the stated range (below it).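

In this assay, chloro in place of fluoro on an aromatic carbon, read here as 4-fluorophenyl to 4-chlorophenyl, gives a 1.1-fold lower number from compound 1 to compound 4 (0.04 log units; within the scatter), so on the core of compound 1 this change leaves the number within the scatter. Taken alone, this step reads differently from the earlier one, which lies beyond the scatter, but the gap between the two steps does not support calling them different: the same change on two cores in this assay, a 2.3-fold higher number (0.36 log units; beyond the scatter) from compound 2 to compound 3 and a 1.1-fold lower number (0.04 log units; within the scatter) from compound 1 to compound 4, 2.5-fold (0.39 log units) apart, within the scatter of two such steps. Within the data shown here, the two steps therefore do not show that the core alters the effect of this change, nor do they establish that the change carries a fixed size from one core to another, since with only one step on each core, and with the core and the place of the change differing together, neither account can be separated from the other.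

The compounds shown leave open whether further matched pairs on other cores would settle on a common step for this change or would spread as widely as these two. They also leave open how a methyl, methoxy or nitrile group in place of the halogen on the 4-fluorophenyl ring of compound 1 would read in this assay.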